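Benzyl for Cyclohexyl on Two Related Amide Chains

The compounds below may be only part of what the source reports. "The series", "measured", "known", "first", "only" and "open" are said of these compounds alone.

Compound 1 `COc1ccc(-c2cc(NC(=O)CCC(=O)N(C)CC(=O)NC3CCCCC3)nc(-c3ccc(OC)cc3)n2)cc1`: 52900 nM
Compound 2 `COc1ccc(-c2cc(NC(=O)CCC(=O)N(C)CC(=O)NCc3ccccc3)nc(-c3ccc(OC)cc3)n2)cc1`: 35400 nM
Compound 3 `COc1ccc(-c2cc(NC(=O)COCC(=O)NCC(=O)NC3CCCCC3)nc(-c3ccc(OC)cc3)n2)cc1`: 21400 nM

In an assay on HeLa cells for displacement of a labelled ligand from adenosine receptor A3 (Homo sapiens), read by fluorescence polarization, with a stated time of 30 min (on this read-out higher numbers stand for weaker inhibition and lower numbers for stronger inhibition), compound 1 gives 52900 nM and compound 2 gives 35400 nM. The two differ in one place, (benzyl in place of cyclohexyl on an amide-type nitrogen), and this gave a 1.5-fold lower number from compound 1 to compound 2 (0.17 log units; within the scatter). Compound 3 gives 21400 nM in this assay; how its core differs from that of compound 1 is not broken down here. Compound 4 `COc1ccc(-c2cc(NC(=O)COCC(=O)NCC(=O)NCc3ccccc3)nc(-c3ccc(OC)cc3)n2)cc1` is not yet measured. It stands to compound 3 as compound 2 stands to compound 1: benzyl in place of cyclohexyl on an amide-type nitrogen, the same change at the same kind of position. Resting on compound 1 and compound 2, whose step was a 1.5-fold lower number from compound 1 to compound 2 (0.17 log units; within the scatter), a similar small step is expected for compound 4, namely a 1.5-fold lower number from compound 3 to compound 4 (0.17 log units; within the scatter). Compound 4 is therefore estimated at 14500 nM, with the likely range from 7000 nM to 30000 nM.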

Compound 4, inhibition constant: 185000 nM
For compound 4 the middle estimate is 13-fold (1.11 log units) below the measured one; the measured number lies above the stated range.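

In this assay, benzyl in place of cyclohexyl on an amide-type nitrogen gave an 8.6-fold higher number from compound 3 to compound 4 (0.94 log units; beyond the scatter). Set beside the earlier case, the change does not carry over with the same effect from one core to the other: the same change on two cores in this assay, a 1.5-fold lower number (0.17 log units; within the scatter) from compound 1 to compound 2 and an 8.6-fold higher number (0.94 log units; beyond the scatter) from compound 3 to compound 4, 13-fold (1.11 log units) apart, beyond the scatter of two such steps. This shows that, in these two pairs, the outcome of the change depends on the core that carries it, but it does not show which part of the two cores is responsible, and two pairs set no rule for the series.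

The compounds shown leave open how a phenethyl group or a methyl group on the same amide-type nitrogen would read on either core. They also leave open how the change would read on a core with a longer chain.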